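This account rests on a few compounds, and the source may have more. Where it says the series, first, only, none or still open, it means among the compounds named here.

Of the compounds shown here, two from this series have been tested in a functional assay on U-937 cells (Homo sapiens) for cytotoxicity, read by MTT assay, with a stated time of 48 h; on this read-out lower numbers stand for stronger inhibition and higher numbers for weaker inhibition. Compound 1 `Fc1ccc2nc(Nc3nc4ccccc4s3)sc2c1` gives 40600 nM; 43500 nM (2 entries), and the repeated entries behind that figure, (the several entries of compound 1 in this assay, 40600 nM; 43500 nM (2 entries)), sit close to one another. Compound 2 `CCOc1ccc2nc(NC(=S)Nc3ccccc3)sc2c1` gives 37700 nM, which is the only number shown for it; a further entry carries no single number. The two compounds thus occupy much the same ground in this assay.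

Compound 3 `Cc1ccc2nc(NC(=S)Nc3ccccc3)sc2c1` has not yet been measured in this assay. It differs from compound 2 in one place: methyl in place of ethoxy on an aromatic carbon. Among the measured compounds shown here, no measured pair in this set shows what such an exchange does, so the step is expected to stay small, most likely within the scatter, with no direction that can be called in advance.

Compound 3 is therefore estimated at 40000 nM in this assay, with a range from 15000 nM to 110000 nM. That estimate means a step of a 1.1-fold higher number from compound 2 to compound 3 (0.03 log units; within the scatter).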

Compound 3, half-maximal inhibitory concentration: > 50000 nM
Compound 3: only a limit was reported; the forecaster's own chance of this, stated with the estimate: 15%; middle value at least 1.2-fold (0.09 log units) away from the limit.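

In this assay compound 3 gives > 50000 nM, which is a limit of the assay and not a number. On these data alone, putting methyl in place of ethoxy on this aromatic carbon of the shared core gives an at least 1.3-fold higher number from compound 2 to compound 3 (0.12 log units; that floor lies within the scatter), so this first look at the position shows no sign that the smaller group lowers the number, while the true size of the step stays unknown. The set holds just one such case: the limit of > 50000 nM in this assay, at which 1 of the 3 values shown sits.

With only ethoxy and methyl seen at this place, no trend with the size of the group can be read from two compounds. As far as these compounds go, what an amine or a longer chain such as propoxy would do on the same carbon remains open, as does whether any group here can bring the number clearly lower.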